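Swapping an alkyne ester chain for a benzyloxyethyl chain

The source may hold more compounds than are shown below. What is called first, only, known or untested is meant among the compounds shown, and "the series" means these compounds.

Three compounds sharing one core, each carrying a nitrophenyl group and two ester groups, have been tested in a functional assay on HEK293 cells for antagonist activity at Voltage-dependent L-type calcium channel subunit alpha-1C (Oryctolagus cuniculus), read by FLIPR; on this read-out lower numbers stand for stronger inhibition and higher numbers for weaker inhibition. Compound 1 `CCCC1=C(C(=O)OCC)C(c2cccc([N+](=O)[O-])c2)C(C(=O)OCC)=C(C)N1` gives 18 nM. Compound 2 `C#CCCOC(=O)C1=C(C)NC(C)=C(C(=O)OC)C1c1cccc([N+](=O)[O-])c1` gives 31 nM. Compound 3 `CCCCCOC(=O)C1=C(C)NC(C)=C(C(=O)OCC)C1c1cccc([N+](=O)[O-])c1` gives 49 nM. The number for compound 2 sits between the other two, and its gap to compound 3 as well as its gap to compound 1 lies within the usual scatter of repeated measurements, so the three compounds cannot be told apart on these numbers.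

Compound 4 `COC(=O)C1=C(C)NC(C)=C(C(=O)OCCOCc2ccccc2)C1c1cccc([N+](=O)[O-])c1` has not yet been measured in this assay. It differs from compound 2 in one place: benzyloxy in place of ethynyl on a saturated chain carbon, two bonds along the chain from an oxygen next to a carbonyl group. The three measured compounds, with their differing ester chains, all land close together, which gives no reason to expect a change beyond the scatter here. The step from compound 2 to compound 4 is therefore expected to be small, a 1.2-fold lower number from compound 2 to compound 4 (0.09 log units; within the scatter). Compound 4 is estimated at 25 nM, with a likely range from 8 nM to 80 nM.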

Compound 4, half-maximal inhibitory concentration: 9 nM
The estimate for compound 4 lay 2.8-fold (0.44 log units) above the measured number; the measured number falls inside the stated range.
By their numbers in this assay, from the lowest: compounds 4, 1, 2 and 3 (each within the scatter of the next, the first and the last beyond it).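

Among the compounds shown here, putting benzyloxy in place of ethynyl at this spot on the ester chain gives a 3.4-fold lower number from compound 2 to compound 4 (0.54 log units; beyond the scatter) in this assay and this is the only step here between compounds that differ in one place. It shows that this saturated chain carbon can carry a larger group, one that brings a six-membered aromatic ring and an added oxygen, with no loss of inhibition; the number in fact falls. No measurement available here explains why it falls.

Left open is which part of the 2-(benzyloxy)ethyl chain goes with the lower number: the aromatic ring, the oxygen or simply the greater length. A plain longer carbon chain, or an amine in place of benzyloxy at this same carbon, would help to tell these apart.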